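Series notes: compound 4 as a carbamoyl follow-on to compound 3

This account rests on a few compounds, and the source may have more. Where it says the series, first, only, none or still open, it means among the compounds named here.

In a functional assay with Oryctolagus cuniculus as the target (a lower number here means a stronger inhibitor, a higher number a weaker inhibitor), compound 1 `CNC(=N)Nc1nc(-c2ccc(OC)cc2)c(-c2ccc(OC)cc2)s1` gives 62 nM. Compound 2 `COc1ccc(-c2nc(/N=C(\N)NC(C)C)sc2-c2ccc(OC)cc2)cc1` reaches only the limit of the assay in this assay, > 100 nM. Compound 3 `COc1ccc(-c2nc(/N=C(\N)n3ccnc3)sc2-c2ccc(OC)cc2)cc1` likewise sits at a limit in this assay, > 100 nM. On the numbers shown compound 3 therefore has no fixed place, and the step that the two limits leave unreadable from compound 2 to compound 3 cannot be sized. The two readable steps, an at least 1.6-fold higher number from compound 1 to compound 2 (0.20 log units; that floor lies within the scatter) and an at least 1.6-fold higher number from compound 1 to compound 3 (0.20 log units; that floor lies within the scatter), both move away from compound 1 by a floor that itself lies within the scatter; the limit of > 100 nM in this assay, at which 2 of the 3 values shown sit, is the whole of what is known at the upper end of the series.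

Compound 4 `COc1ccc(-c2nc(C(N)=O)sc2-c2ccc(OC)cc2)cc1` differs from compound 3 by a group of 3 heavy atoms (1 carbon, 1 nitrogen, 1 oxygen; no ring) in place of a group of 8 heavy atoms (4 carbon, 4 nitrogen; one five-membered aromatic ring with 2 hetero atoms), on an aromatic carbon. Among the compounds with values here, no measured step bears on a change of this kind, since every change so far has kept a guanidine-like unit in place. The expectation rests only on compound 3 standing at a limit, > 100 nM. Compound 4 is expected at 300 nM, within 100 nM to 3000 nM, most probably reported again as a limit. The step that the limit leaves unreadable from compound 3 to compound 4 is thus an estimate with nothing measured to weigh it against.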

Compound 4, half-maximal inhibitory concentration: > 1000 nM
Compound 4 was reported as a limit (the forecaster's own chance of this, stated with the estimate: 70%); at least 3.3-fold (0.52 log units) between middle value and limit.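

In this assay, within the data shown here, carbamoyl on this aromatic carbon, next to the ring nitrogen and next to the ring sulfur, gives the first step that is printed as beyond the scatter (an at least 16-fold higher number from compound 1 to compound 4 (1.20 log units; beyond the scatter)). Among these compounds, the earlier steps away from compound 1 showed only floors within the scatter, so this is the first clear sign that activity at this position depends on which group sits there. Compound 4 is recorded only as a limit of the assay, and its true value is not fixed (> 1000 nM).

The steps from compound 2 and from compound 3 to compound 4 cannot be read, since both ends of each are limits. From the compounds shown here alone, whether an amine or a carboxylic acid on this aromatic carbon would read closer to compound 1 or to compound 4 remains open.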